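A few compounds are considered here, and "the series" means these few. Any claim that something is new, unique, unknown or untested is made for them only; others in the source may bear on it.

In a functional assay on HL-60 cells (Homo sapiens), read by colorimetric assay, with a stated time of 24 h (on this read-out higher numbers stand for weaker inhibition and lower numbers for stronger inhibition), four nucleoside-like compounds come into view: compound 1 `CNc1ncnc2c1ncn2[C@@H]1O[C@H]([C@H](O)CO)[C@@H](O)[C@H]1O`, compound 2 `CNc1nc(Cl)nc2c1ncn2[C@@H]1O[C@H]([C@H](O)CO)[C@@H](O)[C@H]1O`, compound 3 `CC(=O)OC[C@@H](OC(C)=O)[C@H]1O[C@@H](n2cnc3c(Cl)ncnc32)[C@H](OC(C)=O)[C@@H]1OC(C)=O` and the still unmeasured compound 4 `CC(=O)OC[C@@H](OC(C)=O)[C@H]1O[C@@H](n2cnc3c(Cl)nc(Cl)nc32)[C@H](OC(C)=O)[C@@H]1OC(C)=O`. Compound 1 gives only a limit of the assay, > 100000 nM. Compound 2 likewise gives only a limit, > 100000 nM. Within the data shown here, compound 3 is the one compound with a measured number, 79300 nM.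

The step that the two limits leave unreadable from compound 1 to compound 2 rests on (chloro in place of hydrogen on an aromatic carbon); it cannot be read, because the limit of > 100000 nM in this assay, at which 2 of the 3 values shown sit, hides where each of the two truly lies. The core of compound 3 is different from the core of compound 1, and how they differ is not broken down here.

Compound 4 arises from compound 3 by chloro in place of hydrogen on an aromatic carbon. Among the measured compounds shown here, this is the same kind of change as the one from compound 1 to compound 2, not the same: in compound 3 the carbon that receives the chloro lies meta to a chloro group, whereas in compound 1 it lies meta to a methylamino group.

For the measured compounds named here, the expected step of a 1.1-fold lower number from compound 3 to compound 4 (0.05 log units; within the scatter) is therefore little more than a guess, since the only earlier example of this change yields two limits and no readable size. With compound 3 as the only anchor, compound 4 is expected to come out near 70000 nM, within a broad band from 20000 nM to 200000 nM, and it may well give only a limit.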

Compound 4, half-maximal inhibitory concentration: 16100 nM
Estimate against measurement, compound 4: 4.3-fold (0.64 log units) above; the whole stated range lies above it.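

In this assay, chloro in place of hydrogen on an aromatic carbon gives a 4.9-fold lower number from compound 3 to compound 4 (0.69 log units; beyond the scatter), a modest step but one beyond the usual scatter, so on the core of compound 3 this change goes with stronger inhibition. The same change on the core of compound 1, from compound 1 to compound 2, gives no size that can be compared with this step, because neither compound gives a number, only a limit of the assay: the limit of > 100000 nM in this assay, at which 2 of the 4 values shown sit. The series therefore holds one readable example on one core, which shows that the change can lower the number but does not show whether that drop carries over to another core, where the receiving carbon has a methylamino group rather than a chloro group meta to it.

The compounds shown leave open whether a different group on that same aromatic carbon, such as a nitrile or an amino group, would lower the number as chloro does. They also leave open how the methylamino group would behave in place of the chloro group of compound 3, with the acetyl esters kept, a pairing that might bring that group into a range where numbers can be read.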